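Aryl swap on the quinolone nitrogen: expectation for compound 4

The source may hold more compounds than are shown below. What is called first, only, known or untested is meant among the compounds shown, and "the series" means these compounds.

Measured so far:
- compound 1 `O=C(Nc1ccc(Oc2ccnc3[nH]ccc23)cc1)c1cn(-c2ccc(Br)cc2F)c2ccccc2c1=O`, in a functional assay on A549 cells (Homo sapiens) for inhibition, read by MTT assay, with a stated time of 72 h (on this read-out lower numbers stand for stronger inhibition and higher numbers for weaker inhibition), compound 1 gives 1330 nM
- compound 2 `O=C(Nc1ccc(Oc2ccnc3[nH]ccc23)c(F)c1)c1cn(-c2ccccc2)c2ccccc2c1=O`, in this assay compound 2 gives 420 nM
- compound 3 `O=C(Nc1ccc(Oc2ccnc3[nH]ccc23)c(F)c1)c1cn(-c2ccc(F)cc2)c2ccccc2c1=O`, in this assay compound 3 gives 290 nM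

Compound 3 has the lowest number of the three; the gap to compound 2 is within the scatter, the gap to compound 1 is beyond it. Compound 4 `O=C(Nc1ccc(Oc2ccnc3[nH]ccc23)c(F)c1)c1cn(-c2ccc(Br)cc2F)c2ccccc2c1=O` differs from compound 3 by 4-bromo-2-fluorophenyl in place of 4-fluorophenyl on an aromatic nitrogen. Among the compounds with values here, the only single-point step, a 1.4-fold lower number from compound 2 to compound 3 (0.16 log units; within the scatter), concerns a change on the same aryl ring and stayed within the scatter. Within the data shown here, compound 1 carries the same 4-bromo-2-fluorophenyl as compound 4 but a different anilide ring, so no direct step is available; its number sits well above that of compound 3. On that basis compound 4 is expected to give a higher number, a 2.8-fold higher number from compound 3 to compound 4 (0.44 log units; beyond the scatter), estimated at 800 nM with a range of 300 nM to 2000 nM in this assay.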

Compound 4, half-maximal inhibitory concentration: 1150 nM
Compound 4: the middle estimate sits 1.4-fold (0.16 log units) below what was measured; measured number inside the range.
By their numbers in this assay, from the lowest: compounds 3 and 2 (each within the scatter of the next); then compounds 4 and 1 (each within the scatter of the next).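

In this assay only 4-bromo-2-fluorophenyl moves the number beyond the scatter at this position, with a 4.0-fold higher number from compound 3 to compound 4 (0.60 log units; beyond the scatter) and a 2.7-fold higher number from compound 2 to compound 4 (0.44 log units; beyond the scatter). With that aryl group in place, fluoro in place of hydrogen on the anilide ring stays within the scatter, with a 1.2-fold lower number from compound 1 to compound 4 (0.06 log units; within the scatter). The other fluoro step sits on the aryl ring instead, so the two steps differ in place and agree only in size: the same change on two cores in this assay, a 1.4-fold lower number (0.16 log units; within the scatter) from compound 2 to compound 3 and a 1.2-fold lower number (0.06 log units; within the scatter) from compound 1 to compound 4, 1.3-fold (0.10 log units) apart, within the scatter of two such steps.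

The compounds shown do not separate the bromo from the added fluoro on the aryl ring. Also open, going by these compounds, is how an amine or a carboxylic acid on that ring would read.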